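Chloro in place of methoxy at the assay's limit

The source may report more compounds than this note shows. Statements on the series, on what has been measured and on what is new or still open speak of the compounds shown alone.

In a toxicity assay on GES1 cells (Homo sapiens) for inhibition, read by MTT assay, with a stated time of 72 h (a lower number here means a stronger inhibitor, a higher number a weaker inhibitor), compound 2 `COc1ccc(N2CCCC2)c(C(=O)Nc2ccc(CNC(=O)OCc3cccnc3)cc2)c1` gives > 100000 nM, which is a limit of the assay and not a number. Compound 1 `O=C(NCc1ccc(NC(=O)c2cc(-c3ccccc3)ccc2N2CCCC2)cc1)OCc1cccnc1` gives > 100000 nM, which is also a limit. The evidence so far is the limit of > 100000 nM in this assay, at which 2 of the 2 values shown sit.

Compound 3 `O=C(NCc1ccc(NC(=O)c2cc(Cl)ccc2N2CCCC2)cc1)OCc1cccnc1` carries chloro in place of methoxy on an aromatic carbon, meta to a large group and para to a pyrrolidin-1-yl group: chloro in place of methoxy on an aromatic carbon. Among the compounds with values here, the one measured step that bears on this change is a step that the two limits leave unreadable from compound 1 to compound 2. It therefore gives no size to carry over, and no step beyond the scatter can be expected on its evidence, in either direction. The step expected is a number no higher from compound 2 to compound 3 (the limit leaves the size open). A further reading at the limit is the likeliest outcome in this assay. For compound 3 the estimated value is 100000 nM, with an expected range from 40000 nM to 200000 nM.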

Compound 3, half-maximal inhibitory concentration: > 100000 nM
Compound 3 gave a limit, no number (the forecaster's own chance of this, stated with the estimate: 85%); the middle value lies on the limit itself.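

In this assay compound 3 gives > 100000 nM, which is a limit of the assay and not a number. No step can be read among compound 1, compound 2 and compound 3. The compounds shown leave open whether phenyl, methoxy or chloro on that aromatic carbon makes any difference to the toxicity.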